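Shortening the ether side chain of compound 1

The compounds below may be only part of what the source reports. "The series", "measured", "known", "first", "only" and "open" are said of these compounds alone.

Compound 1 `OC1(COc2ccc([C@H]3CC[C@]4(CC3)OOC3(O4)C4CC5CC(C4)CC3C5)cc2)CCNCC1` carries an ether side chain on its shared core. Among the measured compounds shown here, in an ADME assay on microsomes from liver (Homo sapiens) for metabolic stability, read by LC-MS, tested at 1 uM (on this read-out lower numbers stand for slow clearance and higher numbers for fast clearance), compound 1 gives 16 mL.min-1.g-1, the lowest of the three numbers measured so far. Compound 2 `CC(C)(O)CN1CCC(Oc2ccc([C@H]3CC[C@]4(CC3)OOC3(O4)C4CC5CC(C4)CC3C5)cc2)CC1` gives 18 mL.min-1.g-1, and the step is a 1.1-fold higher number from compound 1 to compound 2 (0.05 log units; within the scatter), so the two cannot be told apart. Compound 3 `CS(=O)(=O)N1CCN(CCCOc2ccc([C@H]3CC[C@]4(CC3)OOC3(O4)C4CC5CC(C4)CC3C5)cc2)CC1` gives 68 mL.min-1.g-1; here the step is a 4.3-fold higher number from compound 1 to compound 3 (0.63 log units; beyond the scatter), a real but modest rise. Compound 4 `CC(C)(CN)Oc1ccc([C@H]2CC[C@]3(CC2)OOC2(O3)C3CC4CC(C3)CC2C4)cc1` has not yet been measured. It differs from compound 1 as follows: 1-(aminomethyl)-1-methylethyl in place of (4-hydroxypiperidin-4-yl)methyl on an oxygen on an aromatic ring. Both measured steps bear on this, since each replaces the (4-hydroxypiperidin-4-yl)methyl group by another side chain on the same oxygen, and the outcomes ran from no change beyond the scatter to a modest rise. Neither example, however, leaves the side chain without a ring, so the comparison is indirect. A small upward shift in this assay is expected, one that may well stay within the scatter. The estimated step from compound 1 to compound 4 is a 1.6-fold higher number from compound 1 to compound 4 (0.19 log units; within the scatter). Compound 4 is therefore estimated at 25 mL.min-1.g-1, with a range from 12 mL.min-1.g-1 to 55 mL.min-1.g-1.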

Compound 4, intrinsic clearance in microsomes: < 7 mL.min-1.g-1
Compound 4 gave a limit, no number; the forecaster's own chance of this, stated with the estimate: 5%; middle value at least 3.5-fold (0.55 log units) away from the limit.
By their numbers in this assay, from the lowest: compounds 1 and 2 (each within the scatter of the next); then compound 3. At a limit, below all of these: compound 4.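

Among the compounds shown, compound 4 alone has a side chain without a ring on the oxygen on the aromatic ring, and in this assay it returns a limit of the assay and not a number: the limit of < 7 mL.min-1.g-1 in this assay, at which 1 of the 4 values shown sits. Even so, the direction can be read, with an at least 2.2-fold lower number from compound 1 to compound 4 (0.35 log units; beyond the scatter), and with an at least 2.5-fold lower number from compound 2 to compound 4 (0.41 log units; beyond the scatter). Among the compounds shown here, the earlier steps from compound 1 either stayed within the scatter or went up, so this is the first sign that a change at this position can bring the number down, although the limit leaves the true size of the fall unknown.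

The change from compound 1 to compound 4 removes the ring and the hydroxy group and also alters the size and branching of the side chain, so these compounds cannot show which of these differences matters. From the compounds shown here alone, it also remains open whether an unbranched 2-aminoethyl chain on the same oxygen, or a hydroxy group in place of the amine in 1-(aminomethyl)-1-methylethyl, would give a similarly low reading.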